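A few compounds are considered here, and "the series" means these few. Any claim that something is new, unique, unknown or untested is made for them only; others in the source may bear on it.

Measured in an ADME assay on the whole organism for pharmacokinetics, with Rattus norvegicus as the target, with a stated time of 6 h, at a dose of 10 mg/kg by the oral route; on this read-out higher numbers stand for higher exposure at the dose given and lower numbers for lower exposure:
compound 1 `Cc1cn2c(-c3cn[nH]c3)cnc2c(Nc2cc(Cc3ncccc3F)ns2)n1` gives 569 ng.h/mL
compound 2 `Cc1cn2c(-c3cn[nH]c3)cnc2c(Nc2cc(Cc3cccc(F)n3)ns2)n1` gives 2970 ng.h/mL
compound 3 `Cc1cn2c(-c3cn[nH]c3)cnc2c(Nc2cc(C(c3ccccn3)N3CCCCC3)ns2)n1` gives 99 ng.h/mL

Compound 3 stands lowest of the three numbers in this assay; compound 1 is the nearest to it and compound 2 the furthest, and both gaps lie beyond the scatter. Compound 4 `Cc1cn2c(-c3cn[nH]c3)cnc2c(Nc2cc(C(NC(C)(C)C)c3ccccn3)ns2)n1` has not yet been measured. It differs from compound 3 in one place: (tert-butyl)amino in place of piperidin-1-yl on a saturated chain carbon bound to two aromatic carbons.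

Within the data shown here, the single measured step, a 5.2-fold higher number from compound 1 to compound 2 (0.72 log units; beyond the scatter), concerns an exchange of one fluoropyridinyl for another and leaves the amine part of the molecule untouched. Among the measured compounds shown here, no measured pair exchanges the amine on the saturated chain carbon bound to two aromatic carbons, so nothing measured bears directly on the change from compound 3 to compound 4. The expectation therefore rests on the number of compound 3 alone, with a wide range and no direction assigned.

Compound 4 is expected to give about 120 ng.h/mL in this assay, with a range from 30 ng.h/mL to 450 ng.h/mL. The step this estimate implies, a 1.2-fold higher number from compound 3 to compound 4 (0.08 log units; within the scatter), is expected to stay within the scatter.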

Compound 4, area under the concentration-time curve: 735 ng.h/mL
The estimate for compound 4 lay 6.1-fold (0.79 log units) below the measured number, outside the stated range (above it).
By their numbers in this assay, from the lowest: compound 3; then compounds 1 and 4 (each within the scatter of the next); then compound 2.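

In this assay, the amine on the saturated chain carbon bound to two aromatic carbons now has a measured effect: (tert-butyl)amino in place of piperidin-1-yl gives a 7.4-fold higher number from compound 3 to compound 4 (0.87 log units; beyond the scatter). Exposure in this series therefore shifts with this amine exchange, whereas the earlier measured step concerned only the fluoropyridinyl part. The exchange removes the six-membered non-aromatic ring, adds a hydrogen-bond donor and changes the heavy-atom count all at once, and no measurement available here ties the step to any property of either group.

This single pair cannot separate the loss of the ring from the gain of the donor or from the change in the shape of the amine, and it shows the step only with the unsubstituted pyridinyl group on that carbon. On these data alone, how isopropylamino or morpholin-4-yl on the same carbon would compare with (tert-butyl)amino and piperidin-1-yl remains open, as does whether the step would carry over to a fluoropyridinyl analogue.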